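This account rests on a few compounds, and the source may have more. Where it says the series, first, only, none or still open, it means among the compounds named here.

Working notes on the series. Compound 1 `O=c1[nH]c(=O)n([C@@H]2O[C@@H]3COP(=O)(O)O[C@H]3[C@H]2O)cc1I` gives 722 ug/mL in a functional assay on Raji cells (Homo sapiens); on this read-out lower numbers stand for stronger inhibition and higher numbers for weaker inhibition. Within the data shown here, compound 2 `O=c1[nH]c(=O)n([C@@H]2O[C@@H]3COP(=O)(O)O[C@H]3[C@H]2O)cc1Br` gives 241 ug/mL in this assay, which leaves compound 2 with the lowest of the two numbers so far; the only measured step, a 3.0-fold lower number from compound 1 to compound 2 (0.48 log units; beyond the scatter), separates it from compound 1. Compound 3 `O=c1[nH]c(=O)n([C@@H]2O[C@@H]3COP(=O)(O)O[C@H]3[C@H]2O)cc1Cl` is the next unmeasured member; it differs from compound 2 as follows: chloro in place of bromo on an aromatic carbon. Among the measured compounds shown here, the one step that bears on this change is the halogen swap a 3.0-fold lower number from compound 1 to compound 2 (0.48 log units; beyond the scatter), a modest step toward a lower number. Whether a second halogen swap on the same aromatic carbon carries the trend further cannot be read from a single step, so only a small to modest move toward a lower number is expected in this assay, with no move beyond the scatter also plausible. For compound 3 the expected step is a 1.6-fold lower number from compound 2 to compound 3 (0.21 log units; within the scatter). The estimate for compound 3 is therefore 150 ug/mL, with a range from 50 ug/mL to 500 ug/mL.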

Compound 3, concentration for 50% inhibition: 369 ug/mL
Compound 3: middle estimate off by 2.5-fold (0.39 log units), on the low side; the measured number falls inside the stated range.
By their numbers in this assay, from the lowest: compounds 2, 3 and 1 (each within the scatter of the next, the first and the last beyond it).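

At this aromatic carbon, chloro in place of bromo gives a 1.5-fold higher number from compound 2 to compound 3 (0.19 log units; within the scatter) in this assay, while chloro in place of iodo gives a 2.0-fold lower number from compound 1 to compound 3 (0.29 log units; within the scatter) in the same read-out. Compound 3 therefore lies within the scatter of both compound 1 and compound 2, so the earlier halogen step does not continue as a steady trend, and only compound 1 and compound 2 stand apart from each other beyond the scatter. Nothing on hand explains these numbers.

As far as these compounds go, whether a group other than a halogen on this aromatic carbon, such as methyl, nitrile or an amine, would move the number beyond the scatter stays open. From the compounds shown here alone, whether the three halogens would separate any differently in another read-out also stays open.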